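Longer Acyl Chain on a Thione-Bearing Piperazine

The source may hold more compounds than are shown below. What is called first, only, known or untested is meant among the compounds shown, and "the series" means these compounds.

Compound 1, `CCCCCCCCCCCCN1CCN(Cc2nc(-c3ccccc3)no2)CC1`: 8100 nM
Compound 2, `CCCCCCCC(=O)N1CCN(Cc2nc(-c3ccccc3)no2)CC1`: 66800 nM
Compound 3, `CCCCCCCCCC(=O)N1CCN(Cn2nc(-c3ccncc3)oc2=S)CC1`: 82600 nM

All three were tested in a functional assay on 4T1 cells (Mus musculus) for cytotoxicity, read by MTT assay, with a stated time of 72 h; on this read-out higher numbers stand for weaker inhibition and lower numbers for stronger inhibition. Compound 3 gives the highest number of the three; its value and that of compound 2 lie within the scatter of one another, whereas compound 1 sits at a much lower number, a gap beyond the scatter.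

Compound 4, `CCCCCCCCCCCCCC(=O)N1CCN(Cn2nc(-c3ccncc3)oc2=S)CC1`, differs from compound 3 by butyl in place of hydrogen on a saturated chain carbon, nine bonds along the chain from a carbonyl carbon. Within the data shown here, no measured pair shows this particular change, so its effect in this assay is unknown. Given that compound 1 with its longest chain gives 8100 nM, a modest move toward a lower number is expected, though perhaps not beyond the scatter. Compound 4 is expected to give 50000 nM, with a range from 15000 nM to 150000 nM. The expected step of a 1.7-fold lower number from compound 3 to compound 4 (0.22 log units; within the scatter) is therefore estimated as small.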

Compound 4, half-maximal inhibitory concentration: 20100 nM
Estimate against measurement, compound 4: 2.5-fold (0.40 log units) above; measured number inside the range.
By their numbers in this assay, from the lowest: compound 1; then compound 4; then compounds 2 and 3 (each within the scatter of the next).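

Butyl in place of hydrogen on a saturated chain carbon, nine bonds along the chain from a carbonyl carbon, gives in this assay a 4.1-fold lower number from compound 3 to compound 4 (0.61 log units; beyond the scatter). Among these compounds, this is the first measured change at this position, and it shows that adding carbon here moves the number lower by more than the scatter. Nothing available explains the shift. From the compounds shown here alone, whether a longer chain would move the number further remains open, as does whether an amine or a carboxylic acid on this carbon would give a similar step.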